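From methyl to 4-methoxybenzyl on the amide-type nitrogen

A few compounds are considered here, and "the series" means these few. Any claim that something is new, unique, unknown or untested is made for them only; others in the source may bear on it.

In a functional assay on cells (Cancer cell lines, Homo sapiens) for cytotoxicity, with a stated time of 48 h (on this read-out lower numbers stand for stronger inhibition of growth and higher numbers for weaker inhibition of growth), compound 1 `COc1cc(/C=C2/C(=O)N(C)c3ccc(O)cc32)cc(OC)c1OC` gives 15100 nM, and compound 2 `COc1ccc2c(c1)/C(=C\c1cc(OC)c(OC)c(OC)c1)C(=O)N2C` gives 21900 nM. Within the data shown here, the only measured step is a 1.5-fold higher number from compound 1 to compound 2 (0.16 log units; within the scatter), so compound 2 stands level with compound 1 on these numbers. That step is a methyl in place of hydrogen on an oxygen on an aromatic ring.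

Compound 3 `COc1ccc(CN2C(=O)/C(=C/c3cc(OC)c(OC)c(OC)c3)c3cc(OC)ccc32)cc1` changes a different place: 4-methoxyphenyl in place of hydrogen on a saturated chain carbon bound to an amide-type nitrogen in a ring. Here 4-methoxyphenyl stands in place of hydrogen on a saturated chain carbon bound to an amide-type nitrogen in a ring, turning methyl into 4-methoxybenzyl. Among the measured compounds shown here, no measured compound varies the group at this nitrogen, so the data give no direction, and the small step of a 1.5-fold higher number from compound 1 to compound 2 (0.16 log units; within the scatter) offers only a weak guide to size. The expected result in this assay is a 1.5-fold lower number from compound 2 to compound 3 (0.16 log units; within the scatter), an estimate held loosely. For compound 3 the estimated value is 15000 nM, within an expected range from 4000 nM to 50000 nM.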

Compound 3, concentration for total growth inhibition: 13800 nM
Compound 3: the middle estimate sits 1.1-fold (0.04 log units) above what was measured; measured number inside the range.
By their numbers in this assay, from the lowest: compounds 3, 1 and 2 (each within the scatter of the next).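

In this assay, among these compounds, this is the first look at the group on the amide-type nitrogen, and methyl to 4-methoxybenzyl gives a 1.6-fold lower number from compound 2 to compound 3 (0.20 log units; within the scatter). The position can therefore carry 4-methoxyphenyl, with its 8 heavy atoms and one six-membered aromatic ring of carbon only, without a step beyond the scatter, something the earlier pair, which differed only on an oxygen on an aromatic ring, could not show. No supporting measurement is at hand to explain this result.

The compounds shown leave open how the read-out would respond to a plain benzyl, a longer chain, or an amine or a carboxylic acid on the chain at this nitrogen. On these data alone, with a single step here, it also remains open whether any group at this position can move the number beyond the scatter.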